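The compounds below may be only part of what the source reports. "The series", "measured", "known", "first", "only" and "open" are said of these compounds alone.

In a functional assay (lung parenchyma) for displacement of a labelled ligand, with Cavia porcellus as the target (on this read-out lower numbers stand for stronger inhibition and higher numbers for weaker inhibition), compound 1 `COc1cc(C(=O)NS(=O)(=O)c2ccccc2C)ccc1Cn1cc(CC(C)C(=O)N(C)C)c2ccc(C(=O)NCC3CCCC3)cc21` gives 2.32 nM. Compound 2 `COc1cc(C(=O)NS(=O)(=O)c2ccccc2C)ccc1Cc1nn(C)c2ccc(C(=O)NCC3CCCC3)cc12` gives 1.87 nM, and compound 3 `COc1cc(C(=O)NS(=O)(=O)c2ccccc2C)ccc1Cc1cn(C)c2ccc(C(=O)NCC3CCCC3)cc12` gives 3.21 nM. Compound 1 holds the middle place among these three numbers, but both of the others lie within the usual scatter of it, so this place says little about real differences.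

Compound 4 `CCN(CC)C(=O)/C=C/c1cn(Cc2ccc(C(=O)NS(=O)(=O)c3ccccc3C)cc2OC)c2cc(C(=O)NCC3CCCC3)ccc12` has not yet been measured. It keeps the core of compound 1 and changes one side chain: 2-(diethylcarbamoyl)ethenyl in place of 2-(dimethylcarbamoyl)propyl on an aromatic carbon. In words, 2-(diethylcarbamoyl)ethenyl stands in place of 2-(dimethylcarbamoyl)propyl on an aromatic carbon.

Among the compounds with values here, no measured pair differs by this change alone, so there is no direct precedent for its effect. Within the data shown here, the only guide is that the three measured compounds, though built differently, all give low numbers that stay close together. On that basis, no step beyond the scatter is expected in this assay, in either direction. The expected step is a 1.1-fold higher number from compound 1 to compound 4 (0.03 log units; within the scatter). For compound 4 the estimated value is 2.5 nM, with an expected range of 0.8 nM to 8 nM.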

Compound 4, inhibition constant: 4.9 nM
Estimate against measurement, compound 4: 2.0-fold (0.29 log units) below; the measured number falls inside the stated range.
By their numbers in this assay, from the lowest: compounds 2, 1, 3 and 4 (each within the scatter of the next, the first and the last beyond it).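

In this assay, within the data shown here, putting 2-(diethylcarbamoyl)ethenyl in place of 2-(dimethylcarbamoyl)propyl on this aromatic carbon gives a 2.1-fold higher number from compound 1 to compound 4 (0.32 log units; beyond the scatter), the only single-place step available here and a modest one. It shows that the number responds to the side chain at this position, although compound 4 still gives a low value of 4.9 nM, and that this change is not neutral in this assay. No measurement shown here explains the step.

The change alters the double bonds of the chain and the groups on its amide nitrogen together, so the compounds shown cannot separate the two, leaving open what a chain with only one of these changes would give. Also open, on these data alone, is how this position would respond to a chain ending in a carboxylic acid or an amine.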